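The source may report more compounds than this note shows. Statements on the series, on what has been measured and on what is new or still open speak of the compounds shown alone.

Working notes on the series. Compound 1 `C/C=C/[C@@H](CC(=O)O)NC(=O)[C@@H]1CCCN1S(=O)(=O)c1cc(Cl)cc(Cl)c1` gives 13 nM in an assay on RPMI-8866 cells for inhibition of integrin alpha-4/beta-1 (Homo sapiens); on this read-out lower numbers stand for stronger inhibition and higher numbers for weaker inhibition. Going by the values given here, compound 2 `CC(C)(C)Oc1ccc([C@@H](CC(=O)O)NC(=O)[C@@H]2CCCN2S(=O)(=O)c2cc(Cl)cc(Cl)c2)cc1` gives 0.53 nM, the lowest of the three numbers so far. Compound 3 `O=C(O)C[C@@H](NC(=O)[C@@H]1CCN1S(=O)(=O)c1cc(Cl)cc(Cl)c1)c1ccc(OC(F)F)cc1` differs from compound 2 in several places; in this assay compound 3 gives 1.3 nM. Among the compounds with values here, the one measured single-point step, a 25-fold lower number from compound 1 to compound 2 (1.39 log units; beyond the scatter), concerns replacement of the whole side group rather than a change within the aryl ether. Compound 4 `O=C(O)C[C@@H](NC(=O)[C@@H]1CCCN1S(=O)(=O)c1cc(Cl)cc(Cl)c1)c1ccc(OC(F)(F)F)cc1` carries trifluoromethyl in place of tert-butyl on an oxygen on an aromatic ring. Within the data shown here, no measured step isolates this exchange; the values of compound 2 and compound 3 show only that related aryl ethers stay low. A step no larger than the scatter, perhaps slightly upward, is therefore expected, a 1.9-fold higher number from compound 2 to compound 4 (0.28 log units; within the scatter). Compound 4 is estimated at 1 nM, within 0.3 nM to 3.5 nM.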

Compound 4, half-maximal inhibitory concentration: 2.6 nM
Estimate against measurement, compound 4: 2.6-fold (0.41 log units) below, and the stated range covers the measured number.
By their numbers in this assay, from the lowest: compound 2; then compounds 3 and 4 (each within the scatter of the next); then compound 1.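

On an oxygen on an aromatic ring, trifluoromethyl in place of tert-butyl gives a 4.9-fold higher number from compound 2 to compound 4 (0.69 log units; beyond the scatter) in this assay, so the group on this oxygen matters beyond the scatter. The 4-(trifluoromethoxy)phenyl group still retains part of the gain over prop-1-en-1-yl, with a 5.0-fold lower number from compound 1 to compound 4 (0.70 log units; beyond the scatter). Nothing available explains either step. From the compounds shown here alone, whether methyl or isopropyl on this oxygen would give a number nearer that of compound 2 or that of compound 4 remains open.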